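A few compounds are considered here, and "the series" means these few. Any claim that something is new, unique, unknown or untested is made for them only; others in the source may bear on it.

Of the compounds shown here, two have been tested so far in an ADME assay on MCF-10A cells (Homo sapiens) for inhibition, with a stated time of 48 h (a higher number here means a weaker inhibitor, a lower number a stronger inhibitor), and neither gave a number. Compound 1 `O=C(Nc1ccc([N+](=O)[O-])cc1)N1CCC[C@H]1c1nc(-c2ccccc2)no1` in this assay gives > 50000 nM, which is a limit of the measurement rather than a measured value. Compound 2 `Cc1ccccc1-c1noc([C@@H]2CCCN2C(=O)Nc2ccc(Cl)cc2)n1` in this assay gives > 50000 nM, again a limit and not a number. Going by the values given here, compound 2 thus stands at the limit, and so does the only other value shown (the limit of > 50000 nM in this assay, at which 2 of the 2 values shown sit). Among the compounds with values here, no step between two measured compounds exists here, so nothing is yet known about how a single structural change moves this read-out.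

Compound 3 `O=C(Nc1ccc(Cl)cc1)N1CCC[C@H]1c1nc(-c2ccccc2Br)no1` differs from compound 2 in one place:

bromo in place of methyl on an aromatic carbon

With both measured compounds sitting at the same limit, there is no footing for predicting a change in either direction, and the step expected in this assay is none beyond the usual scatter: a step that the limit leaves unreadable from compound 2 to compound 3. The half-maximal inhibitory concentration of compound 3 in this assay is therefore estimated at about 80000 nM, with a plausible range from 20000 nM to 300000 nM, and it is expected that the assay would most likely again report only a limit.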

Compound 3, half-maximal inhibitory concentration: > 50000 nM
Compound 3: a limit, no number (the forecaster's own chance of this, stated with the estimate: 85%); the middle value lies beyond the limit too.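

In this assay compound 3 gives (> 50000 nM), which is a limit and not a number. The step from compound 2 to compound 3 therefore cannot be read, because both sit at the same limit: (the limit of > 50000 nM in this assay, at which 3 of the 3 values shown sit). The compounds shown leave open how strongly any of them inhibits and how a single structural change moves this read-out.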